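Sigma ligands from a benzylpiperidine series: hydroxyl stereochemistry

The source may report more compounds than this note shows. Statements on the series, on what has been measured and on what is new or still open speak of the compounds shown alone.

Measured compounds:
compound 1 `c1ccc(CC2CCN(CC3COC(c4ccccc4)(c4ccccc4)S3)CC2)cc1`: 12 nM
compound 2 `O=C1C(CN2CCC(Cc3ccccc3)CC2)CCC1(c1ccccc1)c1ccccc1`: 1120 nM
compound 3 `O[C@H]1[C@@H](CN2CCC(Cc3ccccc3)CC2)CCC1(c1ccccc1)c1ccccc1`: 282 nM

In an assay on membranes from brain for displacement of a labelled ligand from Sigma non-opioid intracellular receptor 1 (Cavia porcellus), read by scintillation counting, with a stated time of 150 min (a higher number here means a weaker inhibitor, a lower number a stronger inhibitor), compound 3 gives 282 nM and stands second highest of the three numbers. Its nearest neighbour is compound 2, with a higher number beyond the scatter, and the furthest is compound 1, whose number lies well below both. Compound 4 `O[C@@H]1[C@@H](CN2CCC(Cc3ccccc3)CC2)CCC1(c1ccccc1)c1ccccc1` is the diastereomer of compound 3: the two compounds have the same atoms and bonds and differ only in configuration as drawn: 1 of 2 stereo elements differ; a stereocentre at a saturated ring carbon is drawn S in compound 3 and R in compound 4. Going by the values given here, no measured pair in this set differs only in configuration, so there is no direct precedent for the size of the step. A change in the direction of the hydroxyl relative to the chain carrying the piperidine could shift the number either way; the working expectation is a modest change, not clearly beyond the scatter, estimated as a 1.1-fold lower number from compound 3 to compound 4 (0.05 log units; within the scatter). Compound 4 is therefore expected to give about 250 nM in this assay, within 60 nM to 1000 nM.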

Compound 4, inhibition constant: 229 nM
The estimate for compound 4 lay 1.1-fold (0.04 log units) above the measured number; measured number inside the range.
By their numbers in this assay, from the lowest: compound 1; then compounds 4 and 3 (each within the scatter of the next); then compound 2.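

In this assay, the S to R change at the saturated ring carbon gives a 1.2-fold lower number from compound 3 to compound 4 (0.09 log units; within the scatter), so this stereocentre does not separate the two compounds in this assay. This is the series' first direct reading of configuration alone, and no other structural change enters the comparison: the fact that compounds 3 and 4 differ only in the configuration as drawn

Open, going by these compounds, is what the second stereocentre, drawn alike in compound 3 and compound 4, contributes to the number. Also open, on these data alone, is whether an amine in place of the hydroxyl would show the same indifference to configuration at this carbon.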